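The source may report more compounds than this note shows. Statements on the series, on what has been measured and on what is new or still open speak of the compounds shown alone.

Measured in a functional assay on cells for antagonist activity at C-C chemokine receptor type 1 (Homo sapiens), read by FLIPR and calcium flux; a lower number here means a stronger inhibitor, a higher number a weaker inhibitor:
compound 1 `Cc1c(C(=O)NCc2cccc(C(F)(F)F)c2)cnn1-c1ccccc1Cl`: > 3000 nM, a limit of the assay rather than a number
compound 2 `O=C(NCc1cccc(C(F)(F)F)c1)c1cnn(-c2ccc(Cl)cc2)c1CO`: 1200 nM

Compound 2 carries the only number shown in this assay; the other value, that of compound 1, sits at the limit of > 3000 nM in this assay, at which 1 of the 2 values shown sits. Compound 3 `CN(C)c1c(C(=O)NCc2cccc(C(F)(F)F)c2)cnn1-c1ccc(Cl)cc1` differs from compound 2 by dimethylamino in place of hydroxymethyl on an aromatic carbon. Going by the values given here, no step between measured compounds exists to size this change, so for compound 3 the expectation is a step of about a 1.3-fold higher number from compound 2 to compound 3 (0.10 log units; within the scatter) in this assay, likely not far beyond the scatter. Compound 3 is estimated at 1500 nM, with a range of 500 nM to 5000 nM.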

Compound 3, half-maximal inhibitory concentration: > 3000 nM
Compound 3: a limit, no number; the forecaster's own chance of this, stated with the estimate: 25%; at least 2.0-fold (0.30 log units) between middle value and limit.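

On an aromatic carbon next to the ring nitrogen, dimethylamino is not tolerated as well as hydroxymethyl: this assay gives an at least 2.5-fold higher number from compound 2 to compound 3 (0.39 log units; beyond the scatter). The value of compound 3 is a limit of the assay and not a number, so this step has only a lower bound, and the series now sits largely at that limit: the limit of > 3000 nM in this assay, at which 2 of the 3 values shown sit.

The compounds shown do not separate the loss of the hydroxyl group from the arrival of the two methyl groups on nitrogen. A primary amine or a methoxymethyl group at this position would bear on that question.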